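The source may hold more compounds than are shown below. What is called first, only, known or untested is meant among the compounds shown, and "the series" means these compounds.

Compound 1 `ClCc1ccccc1Cn1cnc2c(Cl)nc(Cl)nc21` in a functional assay on SK-OV-3 cells (Homo sapiens) for cytotoxicity, read by sulforhodamine B assay, with a stated time of 48 h (a lower number here means that less compound is tolerated, a higher number that more compound is tolerated), gives 6910 nM. Compound 3 `Nc1nc(Cl)c2ncn(Cc3ccccc3CCl)c2n1` reaches only a limit of the assay, > 100000 nM. On these data alone, the step of an at least 14-fold higher number from compound 1 to compound 3 (1.16 log units; beyond the scatter) is the change (amino in place of chloro on an aromatic carbon); its true size stays open because the limit of > 100000 nM in this assay, at which 1 of the 3 values shown sits, caps the range. Compound 2 `ClCc1cccc(Cn2cnc3c(Cl)nc(Cl)nc32)c1` has the same atoms as compound 1 joined differently; the difference between the two cores is not broken down here, and in this assay compound 2 is "not determined" (no result reported). Compound 4 `Nc1nc(Cl)c2ncn(Cc3cccc(CCl)c3)c2n1` is reached from compound 2 by amino in place of chloro on an aromatic carbon, the same change as from compound 1 to compound 3, at a place described in identical words. In this assay, as far as these compounds go, compound 4 is therefore expected to show a step of comparable large size toward the limit, resting on the step from compound 1 to compound 3, though with no number for compound 2 the starting point is unknown. Compound 4 is estimated at 150000 nM, between 30000 nM and 600000 nM.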

Compound 4, concentration lethal to 50% of the cells: > 100000 nM
Compound 4 ended at the assay's limit; the forecaster's own chance of this, stated with the estimate: 70%; the middle value does not contradict the limit.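

No new step can be read between compound 2 and compound 4. In this assay compound 4 sits at a limit of the assay, > 100000 nM. The compounds shown leave open how the cores of compound 1 and compound 2 compare.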